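A few compounds are considered here, and "the series" means these few. Any claim that something is new, unique, unknown or untested is made for them only; others in the source may bear on it.

Compound 2 `COC(=O)C(Nc1cc(NS(=O)(=O)/C=C/c2c(OC)cc(OC)cc2OC)ccc1OC)c1ccc(F)cc1` is the weaker of the two measured compounds: in a functional assay on K562 cells (Homo sapiens) for cytotoxicity, read by trypan blue exclusion, with a stated time of 96 h (on this read-out higher numbers stand for weaker inhibition and lower numbers for stronger inhibition), compound 2 gives 2500 nM, the highest of the two numbers, while compound 1 `COC(=O)CNc1cc(NS(=O)(=O)/C=C/c2c(OC)cc(OC)cc2OC)ccc1OC` gives 350 nM. For the measured compounds named here, the only measured step, a 7.1-fold higher number from compound 1 to compound 2 (0.85 log units; beyond the scatter), came from adding 4-fluorophenyl. Compound 3 `COc1cc(OC)c(/C=C/S(=O)(=O)Nc2ccc(OC)c(NC(C)(C)C(=O)O)c2)c(OC)c1` differs from compound 2 by 1-carboxy-1-methylethyl in place of (4-fluorophenyl)(methoxycarbonyl)methyl on a nitrogen on an aromatic ring. Going by the values given here, that change removes the 4-fluorophenyl whose arrival raised the number, so a drop of roughly that size is expected, though the carboxylic acid and the two methyl groups have no measured precedent here. Compound 3 is therefore estimated at 600 nM, between 150 nM and 2500 nM, a step of a 4.2-fold lower number from compound 2 to compound 3 (0.62 log units; beyond the scatter).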

Compound 3, half-maximal inhibitory concentration: 5 nM
The estimate for compound 3 lay 120-fold (2.08 log units) above the measured number; measured number outside the range, below it.
By their numbers in this assay, from the lowest: compound 3; then compound 1; then compound 2.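

At the nitrogen on an aromatic ring, the group can lower the number as well as raise it: 1-carboxy-1-methylethyl gives a 500-fold lower number from compound 2 to compound 3 (2.70 log units; beyond the scatter). The same group also outperforms the smaller (methoxycarbonyl)methyl, with a 70-fold lower number from compound 1 to compound 3 (1.85 log units; beyond the scatter), so the lowest number of the three comes with a group that has no ring. Nothing available explains this gain.

On these data alone, compound 3 carries both a carboxylic acid in place of the methyl ester and two added methyl groups, so the contribution of each remains open. Carboxymethyl, which is the acid without those methyl groups, would help to separate them.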